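A Second Fluorine on the Shared Core

The source may hold more compounds than are shown below. What is called first, only, known or untested is meant among the compounds shown, and "the series" means these compounds.

Compound 2 `COc1ccc2c(c1)[n+]([O-])c(C#N)c(-c1ccccc1)[n+]2[O-]` and compound 1 `COc1ccc2c(c1)[n+]([O-])c(C#N)c(-c1ccc(F)cc1)[n+]2[O-]` differ in a single place: fluoro in place of hydrogen on an aromatic carbon. In a physicochemical assay for lipophilicity, measured as octanol-water partition (a lower number here means a more polar compound, a higher number a more lipophilic compound), compound 2 gives 1.58, while compound 1 gives 1.97, so the change made a step that was a number 0.39 log units higher from compound 2 to compound 1 (beyond the scatter). Compound 3 `Cc1ccc(-c2c(C#N)[n+]([O-])c3cc(F)ccc3[n+]2[O-])cc1` has a different core; how it differs from compound 2 is not broken down here. In this assay compound 3 gives 2.48, the highest of the three values. Compound 4 `Cc1ccc(-c2c(C#N)[n+]([O-])c3cc(F)c(F)cc3[n+]2[O-])cc1` has not yet been measured; it differs from compound 3 by fluoro in place of hydrogen on an aromatic carbon. This is the same kind of change as that from compound 2 to compound 1, not the same one: there the entering fluoro sat para to a large group on a ring of carbon only, whereas here it sits on a ring that is part of a fused or bridged system of two rings, ortho to a fluoro group, meta to a fused ring and para to a fused ring. Among the measured compounds shown here, for compound 4 a step of roughly the earlier size is expected, a number 0.37 log units higher from compound 3 to compound 4 (beyond the scatter), resting on the one measured step of a number 0.39 log units higher from compound 2 to compound 1 (beyond the scatter). Compound 4 is thus estimated at 2.85, with a likely range from 2.55 to 3.15.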

Compound 4, partition coefficient: 2.87
Compound 4: the middle estimate sits 0.02 log units below what was measured; measured number inside the range.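

In this assay the new step is a number 0.39 log units higher from compound 3 to compound 4 (beyond the scatter), and it stands beside the earlier a number 0.39 log units higher from compound 2 to compound 1 (beyond the scatter), so fluoro in place of hydrogen on an aromatic carbon gave steps of the same size on two different cores, even though the entering fluoro in compound 4 sits on a ring that is part of a fused system, ortho to a fluoro group. This shows that, for these two pairs, the step measured on one core was a fair guide to the step on the other, but two pairs are too few to make a rule for the whole series. Nothing here shows why the two steps match.

The compounds shown leave open how an amine, a carboxylic acid or a longer chain entering in place of that hydrogen would shift the result in this assay. They also leave open whether the fluoro step would keep this size on any core beyond these two.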